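The source may hold more compounds than are shown below. What is called first, only, known or untested is meant among the compounds shown, and "the series" means these compounds.

Compound 3 `O=C(Nc1nc2ccc(-c3cnc(Cl)c(NS(=O)(=O)c4ccc(F)cc4)c3)cc2s1)NC1CC1` gives 1750 nM in a functional assay on HCT-116 cells (Homo sapiens) for antiproliferative activity, read by MTT assay, with a stated time of 72 h (on this read-out lower numbers stand for stronger inhibition and higher numbers for weaker inhibition), the highest of the two numbers shown. Compound 1 `CCN(CC)CCNC(=O)Nc1nc2ccc(-c3cnc(OC)c(NS(=O)(=O)c4ccc(F)cc4)c3)cc2s1` gives 300 nM in this assay. Compound 2 `CCCNc1nc2ccc(-c3cnc(Cl)c(NS(=O)(=O)c4ccc(F)cc4)c3)cc2s1` reached only a limit in this assay, > 20000 nM, which is not a number. Going by the values given here, the one measured step, an at least 11-fold lower number from compound 2 to compound 3 (1.05 log units; beyond the scatter), concerns a different change and so says little about the step to compound 4 `CCN(CC)CCNC(=O)Nc1nc2ccc(-c3cnc(Cl)c(NS(=O)(=O)c4ccc(F)cc4)c3)cc2s1`, where the change is 2-(diethylamino)ethyl in place of cyclopropyl on an amide-type nitrogen. Compound 1 carries the same 2-(diethylamino)ethyl group on its amide-type nitrogen, though it differs from compound 4 in another place. Taking the value of compound 1 300 nM as a pointer, compound 4 is expected to give a number near 600 nM, between 150 nM and 2500 nM. That expectation means a step of a 2.9-fold lower number from compound 3 to compound 4 (0.46 log units; beyond the scatter), a lower number and probably beyond the scatter.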

Compound 4, half-maximal inhibitory concentration: 920 nM
Compound 4: middle estimate off by 1.5-fold (0.19 log units), on the low side, and the stated range covers the measured number.
By their numbers in this assay, from the lowest: compound 1; then compounds 4 and 3 (each within the scatter of the next). At a limit, above all of these: compound 2.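

In this assay, the group on the amide-type nitrogen makes no clear difference here, with a 1.9-fold lower number from compound 3 to compound 4 (0.28 log units; within the scatter). With 2-(diethylamino)ethyl held fixed, chloro in place of methoxy on an aromatic carbon does count, with a 3.1-fold higher number from compound 1 to compound 4 (0.49 log units; beyond the scatter). Compound 2 stands at a limit, not a number, so an at least 21-fold lower number from compound 2 to compound 4 (1.33 log units; beyond the scatter) gives only a minimum size for the step, and it shows that this larger carbamoyl group, like cyclopropylcarbamoyl, goes with a much lower number than propyl. On these data alone, whether a morpholine-bearing chain on the same nitrogen would move the number beyond the scatter stays open. So does whether methoxy would give a similar step alongside cyclopropyl.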